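This account rests on a few compounds, and the source may have more. Where it says the series, first, only, none or still open, it means among the compounds named here.

In a functional assay on MDA-MB-231 cells (Homo sapiens), read by microscopy and transwell migration, with a stated time of 24 h (a higher number here means a weaker inhibitor, a lower number a stronger inhibitor), compound 3 `Cn1c(-c2ccc(Br)cc2)cs/c1=N\C(=O)c1ccccc1` gives the lowest of three numbers, 125 nM, while compound 1 `Cn1c(-c2ccccc2Cl)cs/c1=N\C(=O)c1ccccc1` gives 268 nM and compound 2 `Cn1c(-c2cccc(Br)c2)cs/c1=N\C(=O)c1ccccc1` gives 302 nM. Compound 4 `Cn1c(-c2cccc(Cl)c2)cs/c1=N\C(=O)c1ccccc1` differs from compound 3 at one place: 3-chlorophenyl in place of 4-bromophenyl on an aromatic carbon. Changing to 4-bromophenyl gave a 2.4-fold lower number from compound 2 to compound 3 (0.38 log units; beyond the scatter) and also a 2.1-fold lower number from compound 1 to compound 3 (0.33 log units; beyond the scatter), whereas replacing 2-chlorophenyl with 3-bromophenyl gave only a 1.1-fold higher number from compound 1 to compound 2 (0.05 log units; within the scatter). Going by the values given here, no measured pair changes bromine to chlorine alone. Leaving 4-bromophenyl is therefore expected to raise the number modestly in this assay, with an expected step of a 2.2-fold higher number from compound 3 to compound 4 (0.35 log units; beyond the scatter). For compound 4 the estimated value is 280 nM, with an expected range from 140 nM to 550 nM.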

Compound 4, half-maximal inhibitory concentration: 367 nM
Beside the measured number, compound 4's estimate is 1.3-fold (0.12 log units) below it; the measured number falls inside the stated range.
By their numbers in this assay, from the lowest: compound 3; then compounds 1, 2 and 4 (each within the scatter of the next).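

In this assay, 3-chlorophenyl in place of 4-bromophenyl gives a 2.9-fold higher number from compound 3 to compound 4 (0.47 log units; beyond the scatter), so compound 3 stays apart from the other three compounds. Going by these compounds alone, the first direct swap of chloro for bromo gives only a 1.2-fold higher number from compound 2 to compound 4 (0.08 log units; within the scatter), and 3-chlorophenyl in place of 2-chlorophenyl gives a 1.4-fold higher number from compound 1 to compound 4 (0.14 log units; within the scatter), so neither change moves the number beyond the scatter. No measurement shown here accounts for the standing of 4-bromophenyl.

As far as these compounds go, it remains open whether 4-chlorophenyl would match 4-bromophenyl. How an amine or a carboxylic acid on that phenyl ring would behave is also unknown.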